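The source may report more compounds than this note shows. Statements on the series, on what has been measured and on what is new or still open speak of the compounds shown alone.

Measured compounds in a functional assay on U-87MG ATCC cells for antiproliferative activity against U-87 MG (Homo sapiens), read by MTT assay, with a stated time of 72 h; on this read-out higher numbers stand for weaker inhibition and lower numbers for stronger inhibition:
- compound 1 `COc1ncc(-c2ccc3nc(NC(=O)NCCN(C)C)sc3c2)cc1NS(=O)(=O)c1ccc(F)cc1` gives 1020 nM
- compound 2 `CCN(CC)CCNC(=O)Nc1nc2ccc(-c3cnc(OC)c(NS(=O)(=O)c4ccc(F)cc4)c3)cc2s1` gives 390 nM
- compound 3 `CNC(=O)Nc1nc2ccc(-c3cnc(OC)c(NS(=O)(=O)c4ccc(F)cc4)c3)cc2s1` gives 1230 nM

Compound 3 has the highest number of the three, which on this read-out means the weakest inhibition. Its gap to compound 1 lies within the scatter, so those two cannot be told apart; its gap to compound 2 is beyond the scatter, as the step of a 3.2-fold higher number from compound 2 to compound 3 (0.50 log units; beyond the scatter) shows.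

Compound 4 `COc1ncc(-c2ccc3nc(NC(=O)NCCN4CCCCC4)sc3c2)cc1NS(=O)(=O)c1ccc(F)cc1` differs from compound 3 in one place: (piperidin-1-yl)methyl in place of hydrogen on a saturated chain carbon bound to an amide-type nitrogen.

Among the measured compounds shown here, two measured steps bear on this change, both running the other way, from a chain-bearing compound back to compound 3. The step of a 1.2-fold higher number from compound 1 to compound 3 (0.08 log units; within the scatter) shows that removing the smaller (dimethylamino)methyl group changes little. The step of a 3.2-fold higher number from compound 2 to compound 3 (0.50 log units; beyond the scatter) shows that removing the larger (diethylamino)methyl group raises the number beyond the scatter; the related step of a 2.6-fold lower number from compound 1 to compound 2 (0.42 log units; beyond the scatter) points the same way. The entering (piperidin-1-yl)methyl group counts more heavy atoms than either, closer to the diethyl case. A modest lowering is therefore expected for compound 4, of about a 2.5-fold lower number from compound 3 to compound 4 (0.39 log units; beyond the scatter), though with only two reference points the size is uncertain.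

Compound 4 is estimated at 500 nM, within a range from 200 nM to 1400 nM.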

Compound 4, half-maximal inhibitory concentration: 750 nM
Beside the measured number, compound 4's estimate is 1.5-fold (0.18 log units) below it; the range from low to high includes it.
By their numbers in this assay, from the lowest: compounds 2, 4, 1 and 3 (each within the scatter of the next, the first and the last beyond it).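

In this assay, adding the (piperidin-1-yl)methyl group to the saturated chain carbon gives a 1.6-fold lower number from compound 3 to compound 4 (0.21 log units; within the scatter), so compound 4 cannot be told apart from the plain compound 3, even though this change adds a ring-bearing amine chain. The piperidin-1-yl group also cannot be separated from either open-chain amine, as a 1.4-fold lower number from compound 1 to compound 4 (0.13 log units; within the scatter) and a 1.9-fold higher number from compound 2 to compound 4 (0.28 log units; within the scatter) both show, so compound 4 sits within the scatter of all three earlier compounds, while compound 2 remains set apart from compounds 1 and 3. The new result therefore shows that closing the amine into a ring at the end of this chain does not produce a gap from compound 3 beyond the scatter, as the diethylamino group did, and no supporting data here offer an explanation for this.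

As far as these compounds go, it remains open how a pyrrolidin-1-yl or morpholin-4-yl group at the end of this chain, or a longer chain carrying the piperidin-1-yl group, would compare. With gaps this small, repeat measurements of compounds 2 and 4 would be needed to show whether the two truly match.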